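Swapping chloro for fluoro on the aryl ring

The compounds below may be only part of what the source reports. "The series", "measured", "known", "first", "only" and "open" are said of these compounds alone.

Measured in a functional assay on A549 cells (Homo sapiens) for antiproliferative activity, read by MTT assay, with a stated time of 72 h; on this read-out higher numbers stand for weaker inhibition and lower numbers for stronger inhibition:
- compound 1 `COc1ccccc1-c1ccc2ncn(-c3cc(OC)c(OC)c(OC)c3)c2c1`: 4320 nM
- compound 2 `COc1cc(-n2cnc3ccc(-c4ccc(C(C)=O)cc4)cc32)cc(OC)c1OC`: 2510 nM
- compound 3 `COc1cc(-n2cnc3ccc(-c4cccc(Cl)c4)cc32)cc(OC)c1OC`: 7050 nM

Compound 3 sits at the weak end of this small set, level with compound 1 once the usual scatter is allowed for. Only compound 2 is clearly stronger, as the step of a 2.8-fold higher number from compound 2 to compound 3 (0.45 log units; beyond the scatter) shows.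

The next compound is compound 4 `COc1cc(-n2cnc3ccc(-c4cccc(F)c4)cc32)cc(OC)c1OC`, in which fluoro takes the place of chloro on an aromatic carbon: fluoro in place of chloro on an aromatic carbon. Going by the values given here, no measured step exchanges one halogen for another, so the evidence is indirect. The three known steps each replace a whole substituted phenyl group, a far larger edit. Those changes gave a 1.7-fold lower number from compound 1 to compound 2 (0.24 log units; within the scatter), a 1.6-fold higher number from compound 1 to compound 3 (0.21 log units; within the scatter) and a 2.8-fold higher number from compound 2 to compound 3 (0.45 log units; beyond the scatter). Only the last of these exceeds the scatter, and it is modest.

A single-atom swap on the ring of compound 3 is therefore not expected to produce a step beyond the scatter in this assay, and no firm direction can be expected. The estimated change is a 1.2-fold lower number from compound 3 to compound 4 (0.07 log units; within the scatter). For compound 4 the expected value is 6000 nM, with an estimated range from 2800 nM to 12000 nM.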

Compound 4, half-maximal inhibitory concentration: 5270 nM
For compound 4 the middle estimate is 1.1-fold (0.06 log units) above the measured one; the range from low to high includes it.
By their numbers in this assay, from the lowest: compounds 2, 1, 4 and 3 (each within the scatter of the next, the first and the last beyond it).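

In this assay, the step from chloro to fluoro on this ring, a 1.3-fold lower number from compound 3 to compound 4 (0.13 log units; within the scatter), leaves the two compounds indistinguishable, so for this pair, exchanging one halogen for the other at this place makes no readable difference. The comparisons with the other aryl groups also hold up with fluoro in place: the step of a 2.1-fold higher number from compound 2 to compound 4 (0.32 log units; beyond the scatter) is beyond the scatter but modest, as the chloro compound's step from compound 2 was, while the step of a 1.2-fold higher number from compound 1 to compound 4 (0.09 log units; within the scatter) stays within it, so compound 2 with its 4-acetylphenyl group remains clearly stronger than both halogen compounds, and compound 1 cannot be separated from either. No measurement is available that would explain why these two halogens read alike here.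

Chloro and fluoro are the only single-atom groups seen at this place, so it remains open whether something quite different there, such as an amine, a nitrile or a carboxylic acid, would move the number beyond the scatter. Also unresolved is whether the same swap would read alike on a different core.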